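Fixing stereochemistry in a sulfonylmethyl oxadiazole agonist

The source may hold more compounds than are shown below. What is called first, only, known or untested is meant among the compounds shown, and "the series" means these compounds.

Of the compounds shown here, two sharing one core have been measured in a functional assay on HEK293 cells for agonist activity at Glucose-dependent insulinotropic receptor (Homo sapiens), read by cAMP accumulation, with a stated time of 30 min; on this read-out higher numbers stand for larger maximal responses and lower numbers for smaller maximal responses. Compound 1 `CC(O[C@H]1CC[C@]2(CC1)COC(C)(C)C2)c1nc(-c2ccc(C(=O)N(C)C)c(F)c2)no1` gives 86% in this assay. Within the data shown here, compound 2 `CC(O[C@H]1CC[C@]2(CC1)COC(C)(C)C2)c1nc(-c2ccc(CS(C)(=O)=O)c(F)c2)no1` gives 130% in this assay, which places compound 2 highest of the two numbers, with compound 1 as its only neighbour. Among the measured compounds shown here, the one measured step, a number 44 percentage points higher from compound 1 to compound 2 (beyond the scatter), concerns the (methylsulfonyl)methyl group replacing dimethylcarbamoyl on an aromatic carbon.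

Compound 3 `C[C@H](O[C@H]1CC[C@]2(CC1)COC(C)(C)C2)c1nc(-c2ccc(CS(C)(=O)=O)c(F)c2)no1` keeps every atom and bond of compound 2 and differs only in drawn configuration: the two compounds have the same atoms and bonds; at least one stereo element is drawn with a configuration in one of them and without one in the other: 2 of 3 stereo elements differ; a stereocentre at a saturated chain carbon is drawn without a configuration in compound 2 and S in compound 3; a stereocentre at a saturated ring carbon is drawn s in compound 2 and R in compound 3. For the measured compounds named here, no measured step bears on a change of this kind, so the single step from compound 1 to compound 2 offers no guide to its size or direction. Since compound 2 is drawn without a configuration at the chain carbon, compound 3 may be one of the isomers contained in it, and its maximal response is expected to stay close to that of compound 2, with the step of a number 5 percentage points lower from compound 2 to compound 3 (within the scatter) expected to lie within the scatter. Compound 3 is therefore estimated at 125% in this assay, with a range from 100% to 150%.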

Compound 3, largest response reached (reported as percent of maximum), in percent of the reference or control that the assay uses: 106%
Beside the measured number, compound 3's estimate is 19 percentage points above it; the measured number falls inside the stated range.
By their numbers in this assay, from the lowest: compound 1; then compound 3; then compound 2.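

In this assay, the (methylsulfonyl)methyl group and every atom and bond stay the same, yet the drawn stereochemistry comes with a number 24 percentage points lower from compound 2 to compound 3 (beyond the scatter). The earlier step concerned only the aromatic substituent, so it could not show that the response also depends on how the stereo elements are drawn, here with the saturated chain carbon defined as S. Even so, this step cannot be read as a clean contrast between two configurations, and it does not show whether the S form is better or worse than its counterpart, because only one side of the comparison has that centre defined: the fact that one of compounds 2 and 3 is drawn with a defined configuration and the other without, at the place where they differ

The compounds shown leave open how the R form at the saturated chain carbon would respond in this assay, and so whether that isomer accounts for the higher number of compound 2. They also leave open whether the response would hold with an ethyl group on that chain carbon, or with a primary sulfonamide in place of the (methylsulfonyl)methyl group.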